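Benzoyl for pyridinoyl on two anilide cores

The compounds below may be only part of what the source reports. "The series", "measured", "known", "first", "only" and "open" are said of these compounds alone.

Compound 1 `O=C(Nc1cc(C(F)(F)F)ccc1NC1CCCCC1)c1ccncc1` carries a (pyridin-4-yl)carbonyl amide on a core bearing a cyclohexylamino group. In a functional assay on HL-60 cells (Homo sapiens) for cytotoxicity, read by MTT assay, with a stated time of 48 h (a lower number here means a stronger inhibitor, a higher number a weaker inhibitor), compound 1 gives 59200 nM. Compound 2 `O=C(Nc1cc(C(F)(F)F)ccc1NC1CCCCC1)c1ccccc1` differs from compound 1 by phenyl in place of pyridin-4-yl on a carbonyl carbon and in this assay compound 2 gives 34900 nM; the step is a 1.7-fold lower number from compound 1 to compound 2 (0.23 log units; within the scatter). Compound 3 `CCN(CC)c1ccc(C(F)(F)F)cc1NC(=O)c1ccncc1` has the second core, which differs from the core of compound 1 by diethylamino in place of cyclohexylamino on an aromatic carbon. In this assay compound 3 gives 89700 nM, a step of a 1.5-fold higher number from compound 1 to compound 3 (0.18 log units; within the scatter) from compound 1. Among the compounds with values here, no counted step links compound 2 and compound 3; their two values show a gap that goes beyond the scatter, with compound 3 holding the highest number of the three.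

Compound 4 `CCN(CC)c1ccc(C(F)(F)F)cc1NC(=O)c1ccccc1` has not been measured in this assay. It differs from compound 3 by phenyl in place of pyridin-4-yl on a carbonyl carbon. Within the data shown here, this is the same change as the one made from compound 1 to compound 2: the place reads the same word for word on both cores, a carbonyl carbon whose other neighbour is an amide-type nitrogen. The change occurs twice among these compounds, and the one measured occurrence stayed within the scatter. With a single precedent, the expectation rests on that step alone. Among the measured compounds shown here, the step from compound 3 to compound 4 is expected to be a 1.7-fold lower number from compound 3 to compound 4 (0.23 log units; within the scatter), because a 1.7-fold lower number from compound 1 to compound 2 (0.23 log units; within the scatter) is the only measured instance of the same change. Compound 4 is estimated at 53000 nM in this assay. The range for compound 4 is expected to run from 25000 nM to 110000 nM.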

Compound 4, half-maximal inhibitory concentration: "not active" (no number reported)
Compound 4: no number reported; the estimate stays without a comparison.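

In this assay, within the data shown here, compound 4 is reported as "not active" with no number, and no step from compound 3 to compound 4 can be read. No supporting evidence bears on this result. The compounds shown leave open whether phenyl in place of pyridin-4-yl on a carbonyl carbon gives a comparable step on both cores, with the single readable instance remaining a 1.7-fold lower number from compound 1 to compound 2 (0.23 log units; within the scatter).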